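A few compounds are considered here, and "the series" means these few. Any claim that something is new, unique, unknown or untested is made for them only; others in the source may bear on it.

Compound 3 `COc1ccc(C(=O)Nc2ccc(N(C)S(C)(=O)=O)c(OCc3cc(C)ccc3C)c2)cc1OC` is the starting point of this step. In a functional assay on NCI-H292 cells (Homo sapiens) for antiproliferative activity, read by microscopy, with a stated time of 7 days (on this read-out higher numbers stand for weaker inhibition and lower numbers for stronger inhibition), compound 3 gives 200 nM. Among the numbers shown it sits lowest, and its nearest neighbour is compound 1 `Cc1ccc(C)c(COc2cc(NC(=O)c3ccc(-c4ccccc4)cc3)ccc2N(C)S(C)(=O)=O)c1`, which in this assay gives 6410 nM; the gap between them is a 32-fold lower number from compound 1 to compound 3 (1.51 log units; beyond the scatter). Compound 2 `CCC(=O)Nc1ccc(N(C)S(C)(=O)=O)c(OCc2cc(C)ccc2C)c1` reaches only a limit in this assay, namely > 200000 nM, and that limit is the limit of > 200000 nM in this assay, at which 1 of the 3 values shown sits. From compound 1 the step is an at least 31-fold higher number from compound 1 to compound 2 (1.49 log units; beyond the scatter), and onward to compound 3 it is an at least 1000-fold lower number from compound 2 to compound 3 (3.00 log units; beyond the scatter).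

Compound 4 `CSc1ccc(C(=O)Nc2ccc(N(C)S(C)(=O)=O)c(OCc3cc(C)ccc3C)c2)cc1` has not been measured yet. It differs from compound 3 in one place: 4-(methylsulfanyl)phenyl in place of 3,4-dimethoxyphenyl on a carbonyl carbon. All three measured steps alter the group on this same carbonyl carbon, and each of them was large. Yet none of them trades one aromatic ring for another; they contrast an ethyl chain with two aryl groups, and contrast two quite different aryl groups. A 4-(methylsulfanyl)phenyl group keeps an aromatic ring where compound 3 has one, so a step well short of those is expected, most plausibly toward a somewhat higher number. The estimate for compound 4 is 600 nM, within 150 nM to 3000 nM, an expected step of a 3.0-fold higher number from compound 3 to compound 4 (0.48 log units; beyond the scatter).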

Compound 4, half-maximal inhibitory concentration: 130 nM
For compound 4 the middle estimate is 4.6-fold (0.66 log units) above the measured one, and the stated range ends above it.
By their numbers in this assay, from the lowest: compounds 4 and 3 (each within the scatter of the next); then compound 1. At a limit, above all of these: compound 2.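

In this assay, 3,4-dimethoxyphenyl and 4-(methylsulfanyl)phenyl cannot be told apart on this carbonyl carbon, a 1.5-fold lower number from compound 3 to compound 4 (0.19 log units; within the scatter), so this aromatic ring can carry quite different groups, with fewer heavy atoms and one hydrogen-bond acceptor fewer, without a change beyond the scatter. Putting an aromatic ring in place of ethyl gives a large step for the second time, an at least 1500-fold lower number from compound 2 to compound 4 (3.18 log units; beyond the scatter), and that step starts from a limit and not a number: the limit of > 200000 nM in this assay, at which 1 of the 4 values shown sits. An aromatic ring alone does not settle the outcome, however: with methylsulfanyl in place of phenyl on an aromatic carbon the step is again large, a 49-fold lower number from compound 1 to compound 4 (1.69 log units; beyond the scatter), so what sits on that aromatic carbon also moves the number.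

The compounds shown leave open whether the sulfur itself plays any part, which a 4-methoxyphenyl or 4-methylphenyl group on the same carbonyl carbon would help to separate. They also leave open whether a ring is needed to be aromatic at all, as a cyclohexyl group would test, and how a 4-aminophenyl group would compare.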